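The source may hold more compounds than are shown below. What is called first, only, known or untested is meant among the compounds shown, and "the series" means these compounds.

Compound 1 `CCC(CC)(CC(=O)Nc1cccc(OCc2ccc3cc(F)ccc3n2)c1)C(=O)O` is measured in a functional assay on ileum (Cavia porcellus) for antagonist activity at cysteinyl leukotriene receptor (Homo sapiens) (on this read-out higher numbers stand for weaker inhibition and lower numbers for stronger inhibition), at 2 nM. Among the three compounds measured, compound 1 sits second highest: compound 3 `CCC(CC)(CC(=O)Nc1cccc(OCc2ccc3ccc(C(F)(F)F)cc3n2)c1)C(=O)O` gives 3 nM, which lies within the scatter of compound 1, while compound 2 `CCC(CC)(CC(=O)Nc1cccc(OCc2ccc3cc(F)c(F)cc3n2)c1)C(=O)O` gives 0.5 nM, reached by a 4.0-fold lower number from compound 1 to compound 2 (0.60 log units; beyond the scatter). Compound 4 `CCC(CC)(CC(=O)Nc1cccc(OCc2ccc3cc(C)ccc3n2)c1)C(=O)O` differs from compound 1 by methyl in place of fluoro on an aromatic carbon. Within the data shown here, the only measured step adds a fluoro at a different place; no measured pair swaps fluoro for methyl, so nothing directly bears on this change. The step from compound 1 to compound 4 is therefore expected to stay within the scatter, a 1.5-fold higher number from compound 1 to compound 4 (0.18 log units; within the scatter). Compound 4 is estimated to give 3 nM, in a range from 1 nM to 10 nM.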

Compound 4, half-maximal inhibitory concentration: 24 nM
Compound 4: middle estimate off by 8.0-fold (0.90 log units), on the low side; the whole stated range lies below it.
By their numbers in this assay, from the lowest: compound 2; then compounds 1 and 3 (each within the scatter of the next); then compound 4.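

In this assay, swapping fluoro for methyl on this aromatic carbon is far from neutral: a 12-fold higher number from compound 1 to compound 4 (1.08 log units; beyond the scatter). The earlier compounds shown here showed only what adding a second fluoro does; this step shows that the number responds strongly to which single heavy atom this carbon carries, although neither group brings a ring, a hydrogen-bond donor or acceptor, or a net charge. Nothing measured here explains the step. The compounds shown leave open how hydrogen, chlorine or a methoxy group would compare at this carbon.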